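The compounds below may be only part of what the source reports. "The series", "measured", "known", "first", "only" and "open" are said of these compounds alone.

In a functional assay on MGC-803 cells (Homo sapiens) for inhibition, read by MTT assay, with a stated time of 48 h, tested at 20 uM (a higher number here means more inhibition at the concentration tested (going by the name of the read-out), a lower number less inhibition), compound 1 `CCCn1c(SCc2ccc(F)cc2)nc2c1c(=O)[nH]c(=O)n2C` gives 86.5%. Compound 2 `Cn1cnc2c1c(=O)n(CC(=O)N1CCC(F)(F)CC1)c(=O)n2C` gives 11.3%, and compound 3 `C#CCN1CCN(C(=O)Cn2c(=O)c3c(ncn3C)n(C)c2=O)CC1` gives 14.1%. Compound 3 thus stands second highest of the three; its nearest neighbour, compound 2, lies within the usual scatter, while compound 1 sits higher, beyond it. Compound 4 `Cn1cnc2c1c(=O)n(CC(=O)N1CCN(C(=O)/C=C/c3ccccc3)CC1)c(=O)n2C` has not been measured. It differs from compound 3 in one place: (2-phenylethenyl)carbonyl in place of propargyl on an amine nitrogen in a ring. Among the measured compounds shown here, no measured pair shows a change of this kind, so its effect cannot be read from the data. A modest step upward is expected because compound 1 with its own aromatic ring gives 86.5%. Compound 4 is estimated at 25%, within 5% to 55%. The expected step is a number 10.9 percentage points higher from compound 3 to compound 4 (beyond the scatter).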

Compound 4, a percentage reported as inhibition, at one concentration (the size of the read-out at that concentration, not a potency): 9.5%
Estimate against measurement, compound 4: 15.5 percentage points above, within the range that was stated.
By their numbers in this assay, from the lowest: compounds 4, 2 and 3 (each within the scatter of the next); then compound 1.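

On the amine nitrogen in the ring, putting (2-phenylethenyl)carbonyl in place of propargyl gives, in this assay, a number 4.6 percentage points lower from compound 3 to compound 4 (within the scatter). This position therefore takes the larger group, with its six-membered aromatic ring of carbon only, without the number moving beyond the scatter. Nothing available gives a reason for this result. Still open, on these data alone, is whether a benzoyl group, a carboxylic acid or a longer alkyl chain on the same nitrogen would move the number beyond the scatter.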